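Fluoro moved around the ring: from compound 2 to compound 3

The source may report more compounds than this note shows. Statements on the series, on what has been measured and on what is new or still open speak of the compounds shown alone.

Measured compounds:
compound 1, `O=C(CNc1ccccc1F)N[C@H]1CCOC1=O`, > 64000 nM
compound 2, `O=C(CNc1ccccc1)N[C@H]1CCOC1=O`, > 64000 nM

Compound 1 is `O=C(CNc1ccccc1F)N[C@H]1CCOC1=O`. In a functional assay on MCF7 cells (Homo sapiens) for antiproliferative activity, read by MTT assay, with a stated time of 72 h (a lower number here means a stronger inhibitor, a higher number a weaker inhibitor), compound 1 gives only a limit of the assay, > 64000 nM. Compound 2 is `O=C(CNc1ccccc1)N[C@H]1CCOC1=O`. In this assay compound 2 likewise gives only a limit, > 64000 nM, so compound 2 stands at the edge of what the assay can report rather than at a number. The step that the two limits leave unreadable from compound 1 to compound 2 cannot be read, since both of its ends are limits; (the limit of > 64000 nM in this assay, at which 2 of the 2 values shown sit).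

Compound 3 is `O=C(CNc1ccc(F)cc1)N[C@H]1CCOC1=O`. It differs from compound 2 by fluoro in place of hydrogen on an aromatic carbon. Within the data shown here, the one measured step, between compound 1 and compound 2, concerns a fluoro on the same kind of aromatic carbon and gives no readable size, so no measured step informs this change beyond the fact that both neighbours sit at the limit. Compound 3 is therefore expected to give a limit as well, with the step that the limit leaves unreadable from compound 2 to compound 3 expected to be none beyond the scatter. The estimate for compound 3 in this assay is 100000 nM, within 30000 nM to 400000 nM.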

Compound 3, half-maximal inhibitory concentration: > 64000 nM
Compound 3: only a limit was reported; the forecaster's own chance of this, stated with the estimate: 85%; the middle value lies beyond the limit too.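

In this assay compound 2 and compound 3 both give only a limit, so no size can be read for the step between them. The compounds shown leave open how strongly any of the three acts on these cells: the limit of > 64000 nM in this assay, at which 3 of the 3 values shown sit.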